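Acyclic nucleoside series: allyloxy replacing isobutylsulfanyl

The source may report more compounds than this note shows. Statements on the series, on what has been measured and on what is new or still open speak of the compounds shown alone.

Measured compounds in an ADME assay on MOLT-3 cells (Homo sapiens) for cytotoxicity, with a stated time of 7 days; on this read-out lower numbers stand for higher toxicity in this test and higher numbers for lower toxicity in this test:
- Compound 1 `CNc1nc(N)nc2c1ncn2/C=C1/CC1(CO)CO` gives > 20000 nM, a limit of the assay.
- Compound 2 `Nc1nc(OCC(F)(F)F)c2ncn(/C=C3/CC3(CO)CO)c2n1` gives > 20000 nM, also a limit.
- Compound 3 `CC(C)CSc1nc(N)nc2c1ncn2/C=C1/CC1(CO)CO` shows "not determined" (no result reported), that is, no result reported.

Among the measured compounds shown here, the only step between measured neighbours, a step that the two limits leave unreadable from compound 1 to compound 2, connects two limits and so gives no readable size. Where compound 3 stands is therefore not shown by any number; the two further values in this assay are both limits, summarised as the limit of > 20000 nM in this assay, at which 2 of the 3 values shown sit, and nothing places compound 3 apart from them.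

Compound 4 `C=CCOc1nc(N)nc2c1ncn2/C=C1/CC1(CO)CO` differs from compound 3 by allyloxy in place of isobutylsulfanyl on an aromatic carbon. For the measured compounds named here, no measured step bears directly on this change. Both readable neighbours of the shared core sit at the limit, so no shift beyond the scatter is expected in this assay in either direction for compound 4, and a result at the limit again is the most likely outcome.

For compound 4 the expected value in this assay is 25000 nM, with a range from 6000 nM to 100000 nM.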

Compound 4, half-maximal cytotoxic concentration: > 20000 nM
Compound 4: only a limit was reported; the forecaster's own chance of this, stated with the estimate: 75%; the middle value lies beyond the limit too.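

In this assay, among the compounds shown here, compound 4 gives > 20000 nM, a limit, so its steps from compound 1 and compound 2 cannot be read and no new step results. The compounds shown leave open whether any of these groups on the shared core shifts this read-out at all: the limit of > 20000 nM in this assay, at which 3 of the 4 values shown sit.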